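This account rests on a few compounds, and the source may have more. Where it says the series, first, only, none or still open, it means among the compounds named here.

Compound 1 `CCCCCCCCNC(=O)[C@@H](NC(=O)c1ccccc1)[C@@H](C)O` in a functional assay on SiHa cells (Homo sapiens) for cytotoxicity, read by MTT assay, with a stated time of 48 h (on this read-out lower numbers stand for stronger inhibition and higher numbers for weaker inhibition), gives 112000 nM as compound 1.
Compound 2 `CCCCCCCCCCCCNC(=O)[C@@H](NC(=O)c1ccccc1)[C@@H](C)O` gives in this assay 63900 nM as compound 2.
Compound 3 `CCCCCCCCCCCCCCNC(=O)[C@@H](NC(=O)c1ccccc1)[C@@H](C)O` gives in this assay > 200000 nM as compound 3, and this is a limit of the assay rather than a number.

Compound 3 therefore stands at the edge of what this assay reports, at the limit of > 200000 nM in this assay, at which 1 of the 3 values shown sits. The next compound, compound 4 `CCCCCCCCCCCCCCCCCCNC(=O)[C@@H](NC(=O)c1ccccc1)[C@@H](C)O`, differs from compound 3 by butyl in place of hydrogen on a saturated chain carbon, ten or more bonds along the chain from an amide-type nitrogen. Among the compounds with values here, three measured steps bear on such chain lengthening. The step from compound 1 to compound 2 was a 1.8-fold lower number from compound 1 to compound 2 (0.24 log units; within the scatter). Beyond that, lengthening brought an at least 1.7-fold higher number from compound 1 to compound 3 (0.25 log units; that floor lies within the scatter) and an at least 3.1-fold higher number from compound 2 to compound 3 (0.49 log units; beyond the scatter), so the longest chain measured so far already reached the limit. Within the data shown here, nothing among the measured compounds suggests a reversal with a still longer chain; the expectation is that compound 4 remains at or past the limit, and the expected step is a step that the limit leaves unreadable from compound 3 to compound 4. Compound 4 is therefore estimated at 300000 nM, within a range from 150000 nM to 1000000 nM, most likely reported as a limit only.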

Compound 4, half-maximal inhibitory concentration: 38200 nM
Estimate against measurement, compound 4: 7.9-fold (0.90 log units) above, and the stated range ends above it.
By their numbers in this assay, from the lowest: compounds 4, 2 and 1 (each within the scatter of the next, the first and the last beyond it). At a limit, above all of these: compound 3.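

In this assay lengthening the chain did not stay at the limit: butyl in place of hydrogen on a saturated chain carbon, ten or more bonds along the chain from an amide-type nitrogen, gave an at least 5.2-fold lower number from compound 3 to compound 4 (0.71 log units; beyond the scatter). Compared with the shorter chains, the longest chain gave a 1.7-fold lower number from compound 2 to compound 4 (0.22 log units; within the scatter) and a 2.9-fold lower number from compound 1 to compound 4 (0.47 log units; beyond the scatter), so compound 4 is separated from compound 1 but not from compound 2, and compound 3 goes against any steady trend with chain length. The same added butyl therefore gave different steps on different chains: the same change on two cores in this assay, a 1.8-fold lower number (0.24 log units; within the scatter) from compound 1 to compound 2 and an at least 5.2-fold lower number (0.71 log units; beyond the scatter) from compound 3 to compound 4, at least 2.9-fold (0.47 log units) apart, beyond the scatter of two such steps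

On these data alone, compound 3 is known only as a limit, so the full size of its steps stays open. Also open, as far as these compounds go, is whether a longer chain than that of compound 4 would continue this pattern, and what an amine on a saturated chain carbon would do.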